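The source may report more compounds than this note shows. Statements on the series, on what has been measured and on what is new or still open speak of the compounds shown alone.

Measured compounds:
compound 1, `O=C(O)[C@H]1NCC=C[C@@H]1O`, gives 25% in an assay for inhibition of alpha-N-acetylgalactosaminidase (Gallus gallus), tested at 1000 uM; a lower number here means less inhibition, a higher number more inhibition at the concentration tested (going by the name of the read-out)
compound 2, `O=C(O)[C@H]1NCC=C[C@H]1O`, gives 0.2%
compound 3, `O=C(O)[C@H]1NC[C@@H](O)[C@H](O)[C@@H]1O`, gives 11%

Compound 3 stands second highest of the three numbers; compound 2 lies below it beyond the scatter, and compound 1 lies above it beyond the scatter. The account now follows the step from compound 3 to compound 4, `O=C(O)[C@@H]1NC[C@H](O)[C@@H](O)[C@H]1O`, which has not yet been measured in this assay. The change is the two compounds have the same atoms and bonds and differ only in configuration as drawn: 4 of 4 stereo elements differ (all stereocentres are inverted: mirror images); a stereocentre at a saturated ring carbon is drawn S in compound 3 and R in compound 4; a stereocentre at a saturated ring carbon is drawn R in compound 3 and S in compound 4; a stereocentre at a saturated ring carbon is drawn S in compound 3 and R in compound 4; a stereocentre at a saturated ring carbon is drawn R in compound 3 and S in compound 4. For the measured compounds named here, one measured step bears on this kind of change: a number 24.8 percentage points lower from compound 1 to compound 2 (beyond the scatter), and that comparison rests on (the fact that compounds 1 and 2 differ only in the configuration as drawn). There a single inverted stereocentre was enough to take the inhibition down to near nothing. Compound 4 inverts every stereocentre of compound 3, so a drop beyond the scatter is expected, though compound 3 starts from a low value and the room to fall is limited. The step from compound 3 to compound 4 is expected to be a number 8 percentage points lower from compound 3 to compound 4 (within the scatter). Compound 4 is therefore estimated at 3%, within a range from 0% to 12%.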

Compound 4, a percentage reported as inhibition, at one concentration (the size of the read-out at that concentration, not a potency): 4%
The estimate for compound 4 lay 1 percentage points below the measured number; low and high end bracket the measured number.
By their numbers in this assay, from the lowest: compounds 2, 4 and 3 (each within the scatter of the next, the first and the last beyond it); then compound 1.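

In this assay, inverting every stereocentre amounts to a number 7 percentage points lower from compound 3 to compound 4 (within the scatter), so this mirror-image pair cannot be told apart, with compound 3 at 11% and compound 4 at 4%. The earlier single inversion gave a number 24.8 percentage points lower from compound 1 to compound 2 (beyond the scatter), so a clear dependence on configuration seen in one pair does not reappear in the other. The comparison is a clean test of configuration alone: the fact that compounds 3 and 4 differ only in the configuration as drawn

The compounds shown leave open whether inverting just one stereocentre of compound 3 would matter, since only the complete inversion is seen here. They also leave open whether a methyl ester or an amide in place of the carboxylic acid, or an N-benzyl group on the ring nitrogen, would change the inhibition of either mirror-image form.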